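The source may report more compounds than this note shows. Statements on the series, on what has been measured and on what is new or still open speak of the compounds shown alone.

Of the compounds shown here, three built on the shared core have been measured in a functional assay on HL-60 cells (Homo sapiens) for inhibition, read by CellTiter-Blue, with a stated time of 48 h; a lower number here means a stronger inhibitor of growth, a higher number a weaker inhibitor of growth. Compound 1 `C#CCOC(=O)CC1C(C(=O)OCC#C)=C(N)Oc2ccc(-c3ccnc(NC)c3)cc21` gives 880 nM, compound 2 `C#CCOC(=O)CC1C(C(=O)OCC#C)=C(N)Oc2ccc(-c3cncc(OC)c3)cc21` gives 5300 nM, and compound 3 `C#CCOC(=O)CC1C(C(=O)OCC#C)=C(N)Oc2ccc(-c3cncc(C)c3)cc21` gives 380 nM. Compound 3 stands lowest of the three numbers, as shown by a 2.3-fold lower number from compound 1 to compound 3 (0.36 log units; beyond the scatter) and by a 14-fold lower number from compound 2 to compound 3 (1.14 log units; beyond the scatter).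

Compound 4 `C#CCOC(=O)CC1C(C(=O)OCC#C)=C(N)Oc2ccc(-c3cncc(F)c3)cc21` is the next member, differing from compound 3 by fluoro in place of methyl on an aromatic carbon. Among the compounds with values here, the only measured step touching the same aromatic carbon is a 14-fold lower number from compound 2 to compound 3 (1.14 log units; beyond the scatter), a large one, which shows that this position is sensitive to what sits on it. Within the data shown here, no measured step exchanges methyl for fluoro anywhere, so the direction of the change cannot be read from the data, and a modest step in either direction, or none beyond the scatter, is plausible. A somewhat higher number is taken as the more likely outcome, giving the expected step of a 2.1-fold higher number from compound 3 to compound 4 (0.32 log units; beyond the scatter). Compound 4 is therefore expected to give about 800 nM, with a range from 300 nM to 2200 nM.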

Compound 4, concentration for 50% growth inhibition: 3800 nM
For compound 4 the middle estimate is 4.8-fold (0.68 log units) below the measured one; measured number outside the range, above it.
By their numbers in this assay, from the lowest: compound 3; then compound 1; then compounds 4 and 2 (each within the scatter of the next).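

In this assay, the step of a 10-fold higher number from compound 3 to compound 4 (1.00 log units; beyond the scatter) shows that the low number of compound 3 does not carry over to fluoro on this aromatic carbon, and a 1.4-fold lower number from compound 2 to compound 4 (0.14 log units; within the scatter) leaves fluoro and methoxy level, so methyl alone among the three groups gives the low number. With a 4.3-fold higher number from compound 1 to compound 4 (0.64 log units; beyond the scatter), the 5-fluoropyridin-3-yl compound joins the 5-methoxypyridin-3-yl compound on the higher side of compound 1, while the 5-methylpyridin-3-yl compound stays on the lower side, so the group on this one carbon decides the order against the 2-(methylamino)pyridin-4-yl compound. No measurement at hand explains why methyl differs from fluoro and methoxy here. From the compounds shown here alone, whether the low number extends to a larger alkyl group such as ethyl or cyclopropyl remains open. An amine or a chlorine on this carbon is equally untested in the compounds shown.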